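This account rests on a few compounds, and the source may have more. Where it says the series, first, only, none or still open, it means among the compounds named here.

Of the compounds shown here, three built on a shared core have been tested in an assay on isolated protein for inhibition of phosphatidylinositol 4,5-bisphosphate 3-kinase catalytic subunit beta isoform (Homo sapiens); on this read-out lower numbers stand for stronger inhibition and higher numbers for weaker inhibition. Compound 1 `COc1ccc(-c2ccnc(Nc3ccc([N+](=O)[O-])cc3)n2)cc1` gives 537 nM in this assay. For compound 2 `Cc1cccc(Nc2nccc(-c3ccc(Br)cc3)n2)c1` this assay reports only a limit, > 1000 nM. For compound 3 `COc1cccc(Nc2nccc(-c3ccc(F)cc3)n2)c1` the result is likewise a limit, > 1000 nM. Compound 2 therefore stands at the limit of > 1000 nM in this assay, at which 2 of the 3 values shown sit, without a number of its own. Compound 4 `Clc1ccc(Nc2nccc(-c3ccc(Br)cc3)n2)cc1` has not yet been measured; it differs from compound 2 by 4-chlorophenyl in place of 3-methylphenyl on a nitrogen on an aromatic ring. For the measured compounds named here, no measured pair shows this change, and a starting point that is itself a limit gives no footing for a direction, so the expected step that the limit leaves unreadable from compound 2 to compound 4 is taken as none beyond the scatter. Compound 4 is estimated to give about 1500 nM, somewhere between 400 nM and 6000 nM.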

Compound 4, half-maximal inhibitory concentration: 946 nM
Compound 4: the middle estimate sits 1.6-fold (0.20 log units) above what was measured, and the stated range covers the measured number.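

With 4-chlorophenyl on the nitrogen, compound 4 gives 946 nM, the first actual number for a compound with the bromophenyl group shown here. Replacing 3-methylphenyl with 4-chlorophenyl gives an at least 1.0-fold lower number from compound 2 to compound 4 (0.02 log units; that floor lies within the scatter), so no gain in inhibition can be claimed for this change. The true size of the step stays unreadable, as compound 2 has only a limit: the limit of > 1000 nM in this assay, at which 2 of the 4 values shown sit.

Still open, on these data alone, is how 4-methylphenyl would read on this nitrogen, which would help separate the chlorine from its ring location. Also open, as far as these compounds go, is how a phenyl ring carrying an amine or a carboxylic acid would read there.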